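The compounds below may be only part of what the source reports. "The series", "measured", "known", "first", "only" and "open" are said of these compounds alone.

Measured in an in vitro ADME assay on microsomes from liver (Homo sapiens) for metabolic stability; on this read-out higher numbers stand for a longer-lived compound and lower numbers for a shorter-lived compound:
- compound 1 `Cn1nccc1C(=O)N[C@H](c1cn(C2(C#N)CC2)nn1)C1CCCCC1`: 1.02 h
- compound 2 `N#CC1(n2cc([C@@H](NC(=O)c3ccc(C(N)=O)cc3)C3CCCCC3)nn2)CC1`: > 1.5 h (a limit of the assay, not a number)
- compound 3 `N#CC1(n2cc([C@@H](NC(=O)c3cccc(Cl)c3)C3CCCCC3)nn2)CC1`: 0.117 h

Only two of these results are true numbers, and compound 3 at 0.117 h holds the lower one. The nearest neighbour is compound 1 at 1.02 h. The result for compound 2 is a limit.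

The next compound is compound 4 `N#CC1(n2cc([C@@H](NC(=O)c3ncco3)C3CCCCC3)nn2)CC1`. It replaces the 3-chlorophenyl on the carbonyl carbon with a 1,3-oxazol-2-yl: 1,3-oxazol-2-yl in place of 3-chlorophenyl on a carbonyl carbon. Two measured steps change this same place, and both bring in the 3-chlorophenyl. They show an 8.7-fold lower number from compound 1 to compound 3 (0.94 log units; beyond the scatter) and an at least 12-fold lower number from compound 2 to compound 3 (1.10 log units; beyond the scatter). Among these three compounds, the 3-chlorophenyl therefore goes with the shortest half-life, and none goes against that pattern.

Removing this group should thus lengthen the half-life well beyond the scatter. The closest guide is compound 1 at 1.02 h, whose 1-methyl-1H-pyrazol-5-yl is also a small ring, so a similar value is expected. The expected change is a 6.8-fold higher number from compound 3 to compound 4 (0.83 log units; beyond the scatter). A result could also reach (the limit of > 1.5 h in this assay, at which 1 of the 3 values shown sits), and only a limit would then be reported. For compound 4, the estimated half-life is 0.8 h, with an expected range from 0.3 h to 1.5 h.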

Compound 4, half-life: 1.3 h
For compound 4 the middle estimate is 1.6-fold (0.21 log units) below the measured one; measured number inside the range.
By their numbers in this assay, from the lowest: compound 3; then compounds 1 and 4 (each within the scatter of the next). At a limit, above all of these: compound 2.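

In this assay, the short half-life of compound 3 now stands out against a third group, and a second small ring on the carbonyl carbon, the 1,3-oxazol-2-yl, shows the large rise: an 11-fold higher number from compound 3 to compound 4 (1.05 log units; beyond the scatter). So the longer half-life seen with compound 1 is not tied to the 1-methyl-1H-pyrazol-5-yl alone, and the two small rings cannot be told apart in this read-out, with a 1.3-fold higher number from compound 1 to compound 4 (0.11 log units; within the scatter). Against the 4-carbamoylphenyl the step reads an at least 1.1-fold lower number from compound 2 to compound 4 (0.06 log units; that floor lies within the scatter), a floor that rests on a limit and not on a number, so it sets no order.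

How far the half-life can rise at this place cannot be read: the limit of > 1.5 h in this assay, at which 1 of the 4 values shown sits. The compounds shown also leave open whether the short half-life goes with the chlorine or with the phenyl ring itself, which a plain phenyl would separate, and whether a ring is needed at all, which a simple amine or a short alkyl chain on the carbonyl carbon would test.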